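Working notes: from compound 2 to compound 3

The source may hold more compounds than are shown below. What is called first, only, known or untested is meant among the compounds shown, and "the series" means these compounds.

Measured in a functional assay on DU-145 cells (Homo sapiens) for inhibition, read by trypan blue exclusion, with a stated time of 72 h; on this read-out lower numbers stand for stronger inhibition and higher numbers for weaker inhibition:
- compound 1 `Cn1c(=O)c(C(=O)Nc2ccc(F)cc2)cc2cnc(Nc3ccc4[nH]ccc4c3)nc21`: 5000 nM
- compound 2 `Cc1ccc(S(=O)(=O)c2cc3cnc(Nc4cnc5[nH]ccc5c4)nc3n(C)c2=O)cc1`: 25000 nM

Compound 2 has the higher of the two numbers, at 25000 nM, and compound 1 lies lower by more than the usual scatter. Compound 3 `Cc1ccc(S(=O)(=O)c2cc3cnc(Nc4ccc5[nH]ccc5c4)nc3n(C)c2=O)cc1` differs from compound 2 by a single exchange on a nitrogen on an aromatic ring: a group of 9 heavy atoms (8 carbon, 1 nitrogen; one five-membered aromatic ring with 1 hetero atom, one six-membered aromatic ring of carbon only) in place of a group of 9 heavy atoms (7 carbon, 2 nitrogen; one five-membered aromatic ring with 1 hetero atom, one six-membered aromatic ring with 1 hetero atom), on a nitrogen on an aromatic ring. Among the measured compounds shown here, no measured pair isolates this exchange, so the expectation rests on limited evidence. Compound 1 also carries the 1H-indol-5-yl group and gives 5000 nM, but it differs from compound 3 elsewhere as well. A moderate shift toward stronger inhibition in this assay is expected, with an estimated size of a 3.1-fold lower number from compound 2 to compound 3 (0.49 log units; beyond the scatter). For compound 3 the expected value is 8000 nM, with an estimated range of 2500 nM to 25000 nM.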

Compound 3, half-maximal inhibitory concentration: 750 nM
Compound 3: the middle estimate sits 11-fold (1.03 log units) above what was measured; the measured number lies below the stated range.
By their numbers in this assay, from the lowest: compound 3; then compound 1; then compound 2.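

Working notes, continued. In this assay, with the (4-methylphenyl)sulfonyl group held constant, placing 1H-indol-5-yl on the aromatic nitrogen gives a 33-fold lower number from compound 2 to compound 3 (1.52 log units; beyond the scatter) and is a large step, so this position responds strongly to a six-membered aromatic ring of carbon only in place of one with 1 hetero atom. With 1H-indol-5-yl held constant, (4-methylphenyl)sulfonyl in place of (4-fluorophenyl)carbamoyl on an aromatic carbon gives a 6.7-fold lower number from compound 1 to compound 3 (0.82 log units; beyond the scatter) and is a modest step, showing that the second position also contributes. Nothing measured here accounts for either step.

As far as these compounds go, it remains open whether the 1H-indol-5-yl gain carries over to compounds bearing (4-fluorophenyl)carbamoyl. Also open, from the compounds shown here alone, is how a plain phenyl group on the nitrogen, or a carboxylic acid or an amine on the sulfonyl aryl ring, would read in this assay on this core.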